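The compounds below may be only part of what the source reports. "The series", "measured", "known", "first", "only" and "open" are said of these compounds alone.

Measured compounds:
- compound 1, `O=C1CN(C[C@@H]2CCCc3cc(S(=O)(=O)c4cccc(F)c4)ccc32)CCN1`: 6.31 nM
- compound 2, `NC(=O)CNC[C@@H]1CCCc2cc(S(=O)(=O)c3cccc(F)c3)ccc21`: 0.1 nM
- compound 3, `O=S(=O)(O)CCCNC[C@@H]1CCCc2cc(S(=O)(=O)c3cccc(F)c3)ccc21`: 1.26 nM

These three share one core and differ only in the group on the saturated chain carbon bound to a saturated ring carbon. In an assay on isolated protein for displacement of a labelled ligand from 5-hydroxytryptamine receptor 6 (Homo sapiens) (a higher number here means a weaker inhibitor, a lower number a stronger inhibitor), compound 3 stands second highest of the three numbers: a 5.0-fold lower number from compound 1 to compound 3 (0.70 log units; beyond the scatter), while a 13-fold higher number from compound 2 to compound 3 (1.10 log units; beyond the scatter).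

Compound 4, `CN(C[C@@H]1CCCc2cc(S(=O)(=O)c3cccc(F)c3)ccc21)C(N)=O`, is not yet measured. Its difference from compound 3 is carbamoyl(methyl)amino in place of (3-sulfopropyl)amino on a saturated chain carbon bound to a saturated ring carbon. Within the data shown here, no measured step covers this exact exchange. The nearest guides are the modest step of a 5.0-fold lower number from compound 1 to compound 3 (0.70 log units; beyond the scatter) and the large step of a 13-fold higher number from compound 2 to compound 3 (1.10 log units; beyond the scatter), which show that this position tolerates wide swings in either direction. Compound 2 carries the carbamoyl group on the same nitrogen as compound 4, but compound 4 also carries a methyl there, so compound 2 is only a loose guide.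

Compound 4 is therefore expected to give roughly 8 nM in this assay, most likely between 1 nM and 60 nM, meaning the estimated step of a 6.3-fold higher number from compound 3 to compound 4 (0.80 log units; beyond the scatter).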

Compound 4, inhibition constant: 39.8 nM
Estimate against measurement, compound 4: 5.0-fold (0.70 log units) below; measured number inside the range.
By their numbers in this assay, from the lowest: compound 2; then compound 3; then compound 1; then compound 4.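

In this assay, among these compounds, carbamoyl(methyl)amino is the first group at this position to give a higher number than 3-oxopiperazin-1-yl (a 6.3-fold higher number from compound 1 to compound 4 (0.80 log units; beyond the scatter)), which makes compound 4 the weakest of the four. The step from its close relative (carbamoylmethyl)amino is far larger (a 400-fold higher number from compound 2 to compound 4 (2.60 log units; beyond the scatter)), and (3-sulfopropyl)amino also does much better (a 32-fold higher number from compound 3 to compound 4 (1.50 log units; beyond the scatter)), so the way the carbamoyl group is attached to this nitrogen matters greatly, not just its presence. No measurement shown here explains these differences. Still open, going by these compounds, is how the number would shift with a plain carbamoylamino group, without the methyl. Also open, on these data alone, is where a (carboxymethyl)amino group, a carboxylic acid on a shorter chain than the sulfopropyl one, would fall.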